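Anilino in place of furanylmethylamine: an expected step

The source may hold more compounds than are shown below. What is called first, only, known or untested is meant among the compounds shown, and "the series" means these compounds.

The compounds were tested in a functional assay on Jurkat cells (Homo sapiens) for inhibition, read by CCK-8 assay, with a stated time of 48 h; a lower number here means a stronger inhibitor of growth, a higher number a weaker inhibitor of growth. Compound 1 `Cc1ccccc1Nc1nc(NC2CC2)ncc1Cl` gives only a limit there, > 100000 nM. Compound 2 `CN1CCN(c2ccc(Nc3ncc(Cl)c(NCc4ccc(F)cc4)n3)nc2)CC1` likewise reaches only the limit, > 100000 nM. Compound 3 `CN1CCN(c2ccc(Nc3ncc(Cl)c(NCc4ccco4)n3)nc2)CC1` stands at the same limit as well, > 100000 nM. The single step among these compounds, a step that the two limits leave unreadable from compound 2 to compound 3, therefore has no readable size, and the limit of > 100000 nM in this assay, at which 3 of the 3 values shown sit, is all the evidence on hand. Compound 4 `COc1ccc(Nc2nc(Nc3ccc(N4CCN(C)CC4)cn3)ncc2Cl)cc1` differs from compound 3 by 4-methoxyphenyl in place of (furan-2-yl)methyl on a nitrogen on an aromatic ring. Going by the values given here, no measured step bears on this change; neither direction nor size can be drawn from these data, and a limit in this assay remains the likeliest outcome, though a number is possible. Compound 4 is expected to give 50000 nM, between 5000 nM and 200000 nM. This corresponds to an expected step of an at least 2.0-fold lower number from compound 3 to compound 4 (0.30 log units; that floor lies within the scatter).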

Compound 4, concentration for 50% growth inhibition: 11200 nM
Estimate against measurement, compound 4: 4.5-fold (0.65 log units) above, and the stated range covers the measured number.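

In this assay, the place on a nitrogen on an aromatic ring now gives a readable result: 4-methoxyphenyl there produces an at least 8.9-fold lower number from compound 3 to compound 4 (0.95 log units; beyond the scatter), and set against 4-fluorobenzyl it produces an at least 8.9-fold lower number from compound 2 to compound 4 (0.95 log units; beyond the scatter). Both steps are floors, for compound 2 and compound 3 each give only a limit, and compound 4 alone carries a number: the limit of > 100000 nM in this assay, at which 3 of the 4 values shown sit.

Going by these compounds, whether the change rests on the ring itself or on its methoxy group remains open. So does how a plain phenyl, or a phenyl bearing a nitrile or a carboxylic acid instead of methoxy, would read.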